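Isoxazole Amide Replaces Halophenyl in a Weak Series

The source may report more compounds than this note shows. Statements on the series, on what has been measured and on what is new or still open speak of the compounds shown alone.

Compound 1, `O=C(Nc1ccc(Cl)c(-c2nnc3c(Cl)cccn23)c1)c1ccccc1`, gives 73500 nM in a functional assay on U-251 cells (Homo sapiens) for antiproliferative activity, read by MTT assay, with a stated time of 72 h; a higher number here means a weaker inhibitor, a lower number a stronger inhibitor.
Compound 2, `O=C(Nc1ccc(Cl)c(-c2nnc3c(Cl)cccn23)c1)c1cccc(Cl)c1`, gives 43100 nM in this assay.
Compound 3, `O=C(Nc1ccc(Cl)c(-c2nnc3c(Cl)cccn23)c1)c1c(F)cccc1Cl`, gives only a limit, > 100000 nM, in this assay.

For compound 3 the number is not known; it sits at the limit of this assay, (the limit of > 100000 nM in this assay, at which 1 of the 3 values shown sits). Compound 4 is `O=C(Nc1ccc(Cl)c(-c2nnc3c(Cl)cccn23)c1)c1ccon1`; its change from compound 3 is 1,2-oxazol-3-yl in place of 2-chloro-6-fluorophenyl on a carbonyl carbon. For the measured compounds named here, two measured steps bear on it: an at least 2.3-fold higher number from compound 2 to compound 3 (0.36 log units; beyond the scatter) and an at least 1.3-fold higher number from compound 1 to compound 3 (0.13 log units; that floor lies within the scatter). Both end at the limit, so the available evidence leaves open whether a swap of the amide aryl group moves the number beyond the scatter. The expected step for compound 4 is an at least 1.2-fold lower number from compound 3 to compound 4 (0.09 log units; that floor lies within the scatter), an estimate that stays near the limit. Compound 4 is estimated to give about 80000 nM, within 30000 nM to 200000 nM.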

Compound 4, half-maximal inhibitory concentration: > 100000 nM
Compound 4 ended at the assay's limit (the forecaster's own chance of this, stated with the estimate: 40%); middle value at least 1.2-fold (0.09 log units) from the limit.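

At the carbonyl carbon, 1,2-oxazol-3-yl is a second group, after 2-chloro-6-fluorophenyl, that leaves the value at a limit in this assay. Replacing 3-chlorophenyl gives an at least 2.3-fold higher number from compound 2 to compound 4 (0.36 log units; beyond the scatter), whereas replacing phenyl gives an at least 1.3-fold higher number from compound 1 to compound 4 (0.13 log units; that floor lies within the scatter). The step between the two limit compounds, compound 3 and compound 4, cannot be read: the limit of > 100000 nM in this assay, at which 2 of the 4 values shown sit.

On these data alone, it remains open how far compound 3 and compound 4 actually lie past that limit. As far as these compounds go, it is also open whether an amine or a longer alkyl chain on the carbonyl carbon would give a readable number.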